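The compounds below may be only part of what the source reports. "The series", "measured", "known", "first", "only" and "open" are said of these compounds alone.

Three members of the series have a value in an assay on HEK293 cells for displacement of a labelled ligand from 5-hydroxytryptamine receptor 7 (Homo sapiens); a higher number here means a weaker inhibitor, a lower number a stronger inhibitor. Compound 1 `O=C1c2ccccc2S(=O)(=O)N1CCCCCN1CCN(c2ccc(Cl)cc2)CC1` gives 191 nM. Compound 2 `O=C1c2ccccc2S(=O)(=O)N1CCCCN1CCN(c2cccc(Cl)c2Cl)CC1` gives 372 nM. Compound 3 `O=C1c2ccccc2S(=O)(=O)N1CCCCCCN1CCN(c2cccc(Cl)c2Cl)CC1` gives 487 nM. Compound 1 has the lowest of the three numbers; its gap to compound 2 lies within the usual scatter, so no order between those two can be claimed, while its gap to compound 3 lies beyond the scatter. Compound 4 `O=C1c2ccccc2S(=O)(=O)N1CCCCCN1CCN(c2ncccn2)CC1` has not been measured in this assay. It differs from compound 1 in one place: pyrimidin-2-yl in place of 4-chlorophenyl on an amine nitrogen in a ring. Among the compounds with values here, no measured pair shows this change, so there is no step from which its size can be read, and the three measured compounds differ from one another in other places. The change is expected to give a modestly higher number in this assay, and the expected step is a 2.6-fold higher number from compound 1 to compound 4 (0.42 log units; beyond the scatter). Compound 4 is therefore estimated at 500 nM, with an expected range from 150 nM to 1600 nM.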

Compound 4, inhibition constant: 2670 nM
Compound 4: middle estimate off by 5.3-fold (0.73 log units), on the low side; measured number outside the range, above it.
By their numbers in this assay, from the lowest: compounds 1, 2 and 3 (each within the scatter of the next, the first and the last beyond it); then compound 4.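

Within the data shown here, with the chain and the shared core unchanged, pyrimidin-2-yl in place of 4-chlorophenyl gives a 14-fold higher number from compound 1 to compound 4 (1.15 log units; beyond the scatter) in this assay, so this position on an amine nitrogen in a ring is sensitive to the group it carries, which the earlier compounds, differing from one another in other places, could not show. The change removes the chlorine and also brings in 2 ring nitrogens with 2 hydrogen-bond acceptors, and this single step cannot separate those contributions. No measurement here bears on the reason for the rise.

A plain phenyl or a pyridin-2-yl group at this position would help to separate the loss of the chlorine from the gain of ring nitrogens. On these data alone, whether the step keeps its size on a shorter or longer chain also remains open.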